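Lengthening the Methyl Group of Compound 1

This account rests on a few compounds, and the source may have more. Where it says the series, first, only, none or still open, it means among the compounds named here.

In an ADME assay on MRC5 cells (Homo sapiens) for cytotoxicity, read by fluorescence, with a stated time of 24 h (on this read-out higher numbers stand for weaker inhibition and lower numbers for stronger inhibition), compound 1 (`CC1S/C(=N\N=C\c2c(-c3ccc(Br)cc3)[nH]c3ccccc23)NC1=O`) gives > 50000 nM, which is a limit of the assay and not a number. Compound 2 (`O=C1CS/C(=N/N=C/c2c(-c3ccc(Cl)cc3)[nH]c3ccccc23)N1Cc1ccco1`) differs from compound 1 in more than one place. Compound 2 gives a true number of 10800 nM.

Compound 3 (`O=C1N/C(=N/N=C/c2c(-c3ccc(Br)cc3)[nH]c3ccccc23)SC1CCO`) has not been measured yet. It keeps the core of compound 1 and carries a single change, (hydroxymethyl in place of hydrogen on a saturated chain carbon bound to a saturated ring carbon), with hydroxymethyl in place of hydrogen on a saturated chain carbon bound to a saturated ring carbon. The same difference reads as methyl to 2-hydroxyethyl.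

Within the data shown here, no measured pair here differs in just one place, so nothing shows directly what such a change does. The expectation therefore starts from compound 1 and (the limit of > 50000 nM in this assay, at which 1 of the 2 values shown sits). In this assay, no step beyond the usual scatter is expected, and any shift would most likely lean slightly toward stronger inhibition. The estimated step is an at least 1.2-fold lower number from compound 1 to compound 3 (0.09 log units; that floor lies within the scatter). For compound 3 the expected value is 40000 nM, with an estimated range from 15000 nM to 100000 nM.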

Compound 3, half-maximal inhibitory concentration: 15900 nM
Beside the measured number, compound 3's estimate is 2.5-fold (0.40 log units) above it, and the stated range covers the measured number.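

Among these compounds, this is the first pair here that differs in one place, and it shows that the chain on this saturated ring carbon is not a silent spot: in this assay, going from methyl to 2-hydroxyethyl on an otherwise unchanged compound gives an at least 3.1-fold lower number from compound 1 to compound 3 (0.49 log units; beyond the scatter), a move toward stronger inhibition of these cells. Compound 1 gives > 50000 nM, which is a limit of the assay and not a number. The size of the step is therefore known only as a floor, and the real difference could be larger: the limit of > 50000 nM in this assay, at which 1 of the 3 values shown sits.

With a single change at this position, the data cannot separate the effect of the longer chain from that of the hydroxymethyl group it carries, and a plain ethyl or propyl chain in the same place would be the direct comparison. Going by these compounds, whether the end of the chain tolerates other groups also stays open, for example an amine or a carboxylic acid in place of the alcohol, and so does whether the same change acts alike on the chloro-substituted compounds.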